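This account rests on a few compounds, and the source may have more. Where it says the series, first, only, none or still open, it means among the compounds named here.

Compound 1 `CCC(CC)[C@@H]1C(=O)N[C@H](C2Cc3ccccc3C2)C(=O)N1[C@@H](C(=O)N1CCOCC1)c1ccc(C)nc1` belongs to a small set of three closely related compounds measured in an in vivo ADME assay on the whole organism for pharmacokinetics, with Rattus norvegicus as the target, at a dose of 5 mg/kg; on this read-out lower numbers stand for slow clearance and higher numbers for fast clearance. In that assay compound 1 gives 23 mL/min/kg, compound 2 `CCC(CC)[C@@H]1C(=O)N[C@H](C2Cc3ccccc3C2)C(=O)N1[C@@H](C(=O)N1CCOCC1)c1ccc(C)nc1C` gives 15 mL/min/kg and compound 3 `CCC(CC)[C@@H]1C(=O)N[C@H](C2Cc3ccccc3C2)C(=O)N1[C@@H](C(=O)N(C)C)c1ccc(C)nc1` gives 20 mL/min/kg. Compound 1 therefore stands within the scatter of both neighbours, and the three numbers cannot be ranked. Two single changes connect them. Methyl in place of hydrogen on an aromatic carbon gives a 1.5-fold lower number from compound 1 to compound 2 (0.19 log units; within the scatter), and dimethylamino in place of morpholin-4-yl on a carbonyl carbon gives a 1.2-fold lower number from compound 1 to compound 3 (0.06 log units; within the scatter).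

Compound 4 `CC[C@@H](C)[C@@H]1C(=O)N[C@H](C2Cc3ccccc3C2)C(=O)N1[C@@H](C(=O)N1CCOCC1)c1ccc(C)nc1` has not yet been measured. It differs from compound 1 in one place: sec-butyl in place of pentan-3-yl on a saturated ring carbon. This puts sec-butyl in place of pentan-3-yl on a saturated ring carbon, with the rest of the structure unchanged. Neither measured step touches that group, so the data offer no direct guide to this change and only show that two changes elsewhere stayed within the scatter. No shift beyond the scatter is therefore expected in this assay, and no firm direction can be given. The expected outcome is a 1.0-fold lower number from compound 1 to compound 4 (0.02 log units; within the scatter). The estimate for compound 4 is 22 mL/min/kg, with an expected range from 11 mL/min/kg to 42 mL/min/kg.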

Compound 4, clearance: 39 mL/min/kg
Beside the measured number, compound 4's estimate is 1.8-fold (0.25 log units) below it; measured number inside the range.
By their numbers in this assay, from the lowest: compounds 2, 3, 1 and 4 (each within the scatter of the next, the first and the last beyond it).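

Within the data shown here, the swap of pentan-3-yl for sec-butyl gives the first reading at this position, on a saturated ring carbon next to the ring nitrogen, where the earlier steps had changed only the aromatic ring and the carbonyl substituent. In this assay, it gives a 1.7-fold higher number from compound 1 to compound 4 (0.23 log units; within the scatter), so removing one carbon from this branched chain, with one defined stereocentre entering, joins the two earlier single changes in staying within the scatter, and the position shows no clear effect on clearance so far. Nothing shown gives a measured property that could account for this step.

The compounds shown leave open whether other groups at this carbon, such as isopropyl, tert-butyl or cyclohexyl, or the sec-butyl group with its stereocentre inverted, would give a step beyond the scatter. They also leave open whether sec-butyl would behave the same way on the methyl-bearing aromatic ring of compound 2 or alongside the dimethylamino group of compound 3, since each change has been read only from compound 1.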